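The compounds below may be only part of what the source reports. "The series", "measured", "known", "first", "only" and "open" are said of these compounds alone.

Within the data shown here, compound 3, with the structure `CC1(C)N=C(N)N=C(N)N1c1ccccc1C(F)(F)F`, gives 3.03 in an assay on isolated protein for inhibition of Dihydrofolate reductase (Mus musculus), at pH 7.20 (a lower number here means a less potent compound, a higher number a more potent compound, by a factor of ten per unit of this negative logarithm), the highest of the three numbers measured so far. Its nearest neighbour is compound 2, `CC1(C)N=C(N)N=C(N)N1c1ccccc1O`, which gives 2.92, and a number 0.11 log units higher from compound 2 to compound 3 (within the scatter). The furthest is compound 1, `CSc1ccccc1N1C(N)=NC(N)=NC1(C)C`, which gives 2.48, and a number 0.55 log units higher from compound 1 to compound 3 (beyond the scatter); between the other two, a number 0.44 log units higher from compound 1 to compound 2 (beyond the scatter).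

Compound 4, `CC1(C)N=C(N)N=C(N)N1c1ccccc1I`, has not been measured. It differs from compound 3 in one place: iodo in place of trifluoromethyl on an aromatic carbon. Among the measured compounds shown here, no measured step introduces iodo, so the bearing of the earlier steps is indirect: every swap made so far at this one aromatic carbon has moved the number by a modest amount at most, and the two most recent groups sit within the scatter of each other. A step of similar or smaller size is therefore expected in this assay, with no clear direction. The expected step from compound 3 to compound 4 is a number 0.02 log units higher from compound 3 to compound 4 (within the scatter). Compound 4 is estimated at 3.05, in a range from 2.55 to 3.55.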

Compound 4, logarithm of the reciprocal of the active concentration, log(1/C): 2.49
The estimate for compound 4 lay 0.56 log units above the measured number, and the stated range ends above it.
By their numbers in this assay, from the lowest: compounds 1 and 4 (each within the scatter of the next); then compounds 2 and 3 (each within the scatter of the next).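

In this assay, this position responds to the swap to iodo: a number 0.54 log units lower from compound 3 to compound 4 (beyond the scatter) and a number 0.43 log units lower from compound 2 to compound 4 (beyond the scatter), so the position is not as indifferent as the close pair of compound 2 and compound 3 suggested. Methylsulfanyl no longer stands alone at the low end, since a number 0.01 log units higher from compound 1 to compound 4 (within the scatter), and the four groups now fall into two pairs, with iodo and methylsulfanyl below hydroxy and trifluoromethyl. No measurement here accounts for this split.

As far as these compounds go, it remains open whether chloro, bromo, methoxy, an amine or a carboxylic acid on this aromatic carbon would join the upper pair, the lower pair or neither. The same swaps on other carbons of the aromatic ring also remain to be compared.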